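Notes: 1-benzothiophen-2-yl replaced in compound 3

The compounds below may be only part of what the source reports. "The series", "measured", "known", "first", "only" and "open" are said of these compounds alone.

In a toxicity assay on MT4 cells (Homo sapiens) for cytotoxicity, read by MTT assay, with a stated time of 5 days (a higher number here means that more compound is tolerated, a lower number that less compound is tolerated), compound 1 `Cc1cnc(Nc2ccc(C#N)cc2)nc1Nc1c(F)cc(-c2ccoc2)cc1F` gives 4200 nM and compound 2 `Cc1cnc(Nc2ccc(C#N)cc2)nc1Nc1c(F)cc(-c2ccsc2)cc1F` gives 261000 nM as its value. Compound 3 `Cc1cc(-c2cc3ccccc3s2)cc(C)c1Nc1ccnc(Nc2ccc(C#N)cc2)n1` reads 138000 nM in this assay and so lies within the scatter of compound 2 and clearly higher than compound 1.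

Compound 4 `Cc1ccc(-c2cc(C)c(Nc3ccnc(Nc4ccc(C#N)cc4)n3)c(C)c2)s1` carries 5-methylthiophen-2-yl in place of 1-benzothiophen-2-yl on an aromatic carbon of the shared core.

Within the data shown here, the one measured single-place step is a 62-fold higher number from compound 1 to compound 2 (1.79 log units; beyond the scatter) and it is large. It bears only indirectly, since it removes furan-3-yl, a group absent from both compound 3 and compound 4, and it sits on a different core. Compound 2 at 261000 nM has a sulfur-containing ring and matches compound 3 within the scatter, so no step beyond the scatter is expected in this assay here.

The estimated outcome is a 1.2-fold lower number from compound 3 to compound 4 (0.06 log units; within the scatter) with no clear direction expected. Compound 4 is expected at 120000 nM with an estimated range from 35000 nM to 300000 nM in this read-out.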

Compound 4, half-maximal cytotoxic concentration: 28000 nM
Compound 4: the middle estimate sits 4.3-fold (0.63 log units) above what was measured; measured number below the stated range.
By their numbers in this assay, from the lowest: compound 1; then compound 4; then compounds 3 and 2 (each within the scatter of the next).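

Working from this assay on the shared core, the position para to a large group and meta to two methyl groups does not treat all sulfur-bearing five-membered aromatic rings alike: 5-methylthiophen-2-yl in place of 1-benzothiophen-2-yl gives a 4.9-fold lower number from compound 3 to compound 4 (0.69 log units; beyond the scatter) and the size of this step is modest. Unlike the earlier step on the core of compound 1, this change keeps the ring sulfur and alters what surrounds it, so a sulfur-bearing ring at this position does not by itself fix the number. Nothing shown accounts for the step.

From the compounds shown here alone, the fused six-membered ring leaves and the methyl enters in one change, so their separate shares remain open. Also open, going by these compounds, is how this position responds to plain thiophen-2-yl, or to an amine or a carboxylic acid on the five-membered ring.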